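A few compounds are considered here, and "the series" means these few. Any claim that something is new, unique, unknown or untested is made for them only; others in the source may bear on it.

Compound 1 `CCN1CCCC1CNC(=O)c1cc(NS(N)(=O)=O)ccc1OC`, compound 2 `CCN1CCCC1CNC(=O)c1cc(NS(N)(=O)=O)c(C)cc1OC` and compound 3 `CCN1CCCC1CNC(=O)c1cc(N(C)S(N)(=O)=O)ccc1OC` have been measured in a functional assay on the whole organism for inhibition, with Canis familiaris (Canis lupus familiaris) as the target; on this read-out lower numbers stand for an effect already at smaller amounts and higher numbers for an effect only at larger amounts of compound. In this assay compound 1 gives 10 mg/kg. In this assay compound 3 gives 1 mg/kg. Compound 2 gives > 1 mg/kg in this assay, and that value is a limit of the assay rather than a number.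

Compound 3 differs from compound 1 by methyl in place of hydrogen on a sulfonamide nitrogen, and that change made a 10-fold lower number from compound 1 to compound 3 (1.00 log units; beyond the scatter). Compound 2 differs from compound 1 by methyl in place of hydrogen on an aromatic carbon, and here the step is a step that the limit leaves unreadable from compound 1 to compound 2, because compound 2 sits at the limit of > 1 mg/kg in this assay, at which 1 of the 3 values shown sits.

Compound 4 `CCN1CCCC1CNC(=O)c1cc(N(C)S(N)(=O)=O)c(C)cc1OC` is not yet measured in this assay. It differs from compound 3 by methyl in place of hydrogen on an aromatic carbon. Among the measured compounds shown here, this is the same kind of change as the one from compound 1 to compound 2, though not the same: in compound 2 the methyl enters ortho to a sulfamoylamino group, whereas in compound 4 it enters ortho to a methyl(sulfamoyl)amino group. The two cores differ by methyl in place of hydrogen on a sulfonamide nitrogen.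

For the measured compounds named here, the only earlier example of this change gives no readable size, so the expectation for compound 4 rests mainly on compound 3 at 1 mg/kg. Compound 4 is expected to lie near compound 3, with the step estimated as a 2.0-fold higher number from compound 3 to compound 4 (0.30 log units; within the scatter). The estimate for compound 4 in this assay is 2 mg/kg, with a wide range from 0.5 mg/kg to 10 mg/kg.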

Compound 4, dose for half-maximal effect: 1 mg/kg
Compound 4: the middle estimate sits 2.0-fold (0.30 log units) above what was measured, within the range that was stated.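

In this assay the methyl on the aromatic carbon, ortho to a methyl(sulfamoyl)amino group, gave no change at the digits printed from compound 3 to compound 4 (within the scatter). The methyl on the sulfonamide nitrogen now stands on a second core, where it gave a number no higher from compound 2 to compound 4 (the limit leaves the size open). The comparison between the two cases remains unsettled: the same change on two cores in this assay, a 10-fold lower number (1.00 log units; beyond the scatter) from compound 1 to compound 3 and a number no higher (the limit leaves the size open) from compound 2 to compound 4; the limit leaves it open whether they differ. The data therefore neither show that the lower number seen on the core of compound 1 carries over to the core of compound 2 nor show that it fails to, and neither the step from compound 1 to compound 2 nor the size of the step on the second core can be read, as the value of compound 2 is a limit: the limit of > 1 mg/kg in this assay, at which 1 of the 4 values shown sits.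

The compounds shown leave open what chlorine, an ethyl group or a longer chain would do on the aromatic carbon that carries the methyl in compound 4, as a methyl is the only group there. They also leave open what an ethyl group or a longer chain would do on the sulfonamide nitrogen, and whether a second methyl on the terminal amine of the sulfamoyl group would change the number in this assay.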